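Aryl swap on a compound at the assay limit

The source may hold more compounds than are shown below. What is called first, only, known or untested is meant among the compounds shown, and "the series" means these compounds.

Compound 1 `CCOC(=O)c1c(-c2cccc(Oc3ccccc3)c2)[nH]c2cc(OC)c(Cl)cc2c1=O` and compound 2 `CCOC(=O)c1c(-c2cccc(Cl)c2)[nH]c2cc(OC)c(Cl)cc2c1=O` share one core. In an ADME assay on HEK293 cells (Homo sapiens) for cytotoxicity, read by luminescence, with a stated time of 72 h (on this read-out lower numbers stand for an effect already at smaller amounts and higher numbers for an effect only at larger amounts of compound), compound 1 gives > 22000 nM, which is a limit and not a number. Compound 2 gives > 22000 nM, also a limit, so its position is known only as the limit of > 22000 nM in this assay, at which 2 of the 2 values shown sit. Compound 3 `CCOC(=O)c1c(-c2cc(F)cc(OC)c2)[nH]c2cc(OC)c(Cl)cc2c1=O` carries 3-fluoro-5-methoxyphenyl in place of 3-chlorophenyl on an aromatic carbon. Among the measured compounds shown here, the only measured step on this aryl group is a step that the two limits leave unreadable from compound 1 to compound 2, and it offers no size to carry over. On that evidence, no change beyond the usual scatter is expected in this assay, in either direction, and the estimated step is a step that the limit leaves unreadable from compound 2 to compound 3. Compound 3 is expected at 25000 nM, with an estimated range of 12000 nM to 50000 nM, and it will most likely be reported only as a limit.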

Compound 3, half-maximal effective concentration: > 22000 nM
Compound 3: only a limit was reported; the forecaster's own chance of this, stated with the estimate: 85%; the middle value lies beyond the limit too.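

Compound 2 and compound 3 are both reported only as limits, so no size can be read for the step between them. Compound 1, compound 2 and compound 3 leave open how these aryl groups on the shared core differ in this assay, since all sit at one value: the limit of > 22000 nM in this assay, at which 3 of the 3 values shown sit.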